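Amide variation on the shared core: chloropyridine exchange

A few compounds are considered here, and "the series" means these few. Any claim that something is new, unique, unknown or untested is made for them only; others in the source may bear on it.

Compound 1 `CC(C)(CCl)C(=O)Nc1cccc(-c2nc3ccccc3s2)c1` and compound 2 `O=C(Nc1cccc(-c2nc3ccccc3s2)c1)c1ccc(Cl)nc1Cl` share one core and differ only in the group on the carbonyl carbon of the amide. In an ADME assay on Raji cells (Homo sapiens) for inhibition, with a stated time of 72 h (on this read-out lower numbers stand for an effect already at smaller amounts and higher numbers for an effect only at larger amounts of compound), compound 1 gives only a limit of the assay, > 25000 nM. In this assay compound 2 likewise returns a limit, > 25000 nM. The step that the two limits leave unreadable from compound 1 to compound 2 is unreadable, as both values sit at the limit of > 25000 nM in this assay, at which 2 of the 2 values shown sit. Compound 2 thus stands at the boundary of what the assay reports, with no measured number of its own.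

Compound 3 `O=C(Nc1cccc(-c2nc3ccccc3s2)c1)c1ccnc(Cl)c1` differs from compound 2 by 2-chloropyridin-4-yl in place of 2,6-dichloropyridin-3-yl on a carbonyl carbon. Among the compounds with values here, no measured step reads on this exchange: the one measured step, from compound 1 to compound 2, has no readable size, and no direction can be drawn from it. Compound 2 sits at the limit in this assay. For compound 3 a step of a number no higher from compound 2 to compound 3 (the limit leaves the size open) of no readable size is expected, most likely ending again at the limit. The estimate for compound 3 in this assay is 25000 nM, with a range from 8000 nM to 100000 nM.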

Compound 3, half-maximal effective concentration: > 25000 nM
Compound 3 ended at the assay's limit; the forecaster's own chance of this, stated with the estimate: 80%; the middle value lies on the limit itself.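

In this assay compound 3 gives > 25000 nM as a limit of the assay, not a number. Within the data shown here, no step among compound 1, compound 2 and compound 3 can be read, since all three end at the same limit: the limit of > 25000 nM in this assay, at which 3 of the 3 values shown sit.

The compounds shown leave open how far these three amides lie from one another and which group on the carbonyl carbon would give a measured number.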